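A few compounds are considered here, and "the series" means these few. Any claim that something is new, unique, unknown or untested is made for them only; others in the source may bear on it.

In a functional assay on FM3A cells (Mus musculus) for cytotoxicity, read by cell counting, with a stated time of 2 days (a lower number here means a stronger inhibitor, a higher number a weaker inhibitor), the three measured compounds give these numbers:

compound 1, `Nc1ccc(/C=C2\SC(=O)N(Cc3cccc(Cl)c3)C2=O)cc1`: 10000 nM
compound 2, `Nc1ccc(/C=C2\SC(=O)N(Cc3cccc(F)c3)C2=O)cc1`: 121000 nM
compound 3, `C=C(Br)C(=O)Nc1ccc(/C=C2\SC(=O)N(Cc3cccc(Cl)c3)C2=O)cc1`: 6100 nM

Compound 4, `C=C(Br)C(=O)Nc1ccc(/C=C2\SC(=O)N(Cc3cccc(F)c3)C2=O)cc1`, has not yet been measured in this assay. It differs from compound 3 by fluoro in place of chloro on an aromatic carbon. The same change has already been made once, from compound 1 to compound 2, as fluoro in place of chloro on an aromatic carbon, and there it gave a 12-fold higher number from compound 1 to compound 2 (1.08 log units; beyond the scatter). The two cores on which the change sits differ by (1-bromoethenyl)carbonyl in place of hydrogen on a nitrogen on an aromatic ring, a difference that gave only a 1.6-fold lower number from compound 1 to compound 3 (0.21 log units; within the scatter). Since the place of the change reads the same in both pairs, a step of similar size is expected, namely an 11-fold higher number from compound 3 to compound 4 (1.06 log units; beyond the scatter), resting on compound 1 to compound 2 having given a 12-fold higher number from compound 1 to compound 2 (1.08 log units; beyond the scatter). Compound 4 is therefore estimated at 70000 nM, with an expected range from 25000 nM to 200000 nM.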

Compound 4, half-maximal inhibitory concentration: 4000 nM
Estimate against measurement, compound 4: 18-fold (1.24 log units) above; the measured number lies below the stated range.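

In this assay, the swap of chloro for fluoro does not carry over to the core bearing the (1-bromoethenyl)carbonyl group, where it gives a 1.5-fold lower number from compound 3 to compound 4 (0.18 log units; within the scatter), and the two steps differ: the same change on two cores in this assay, a 12-fold higher number (1.08 log units; beyond the scatter) from compound 1 to compound 2 and a 1.5-fold lower number (0.18 log units; within the scatter) from compound 3 to compound 4, 18-fold (1.27 log units) apart, beyond the scatter of two such steps Read the other way, adding that group to the nitrogen gives a 30-fold lower number from compound 2 to compound 4 (1.48 log units; beyond the scatter), which also differs from its earlier step: the same change on two cores in this assay, a 1.6-fold lower number (0.21 log units; within the scatter) from compound 1 to compound 3 and a 30-fold lower number (1.48 log units; beyond the scatter) from compound 2 to compound 4, 18-fold (1.27 log units) apart, beyond the scatter of two such steps So across these four compounds the size of each change depends on the other, but this rests on a single pair per core and shows neither why this happens nor how the change would behave on any other core.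

The compounds shown leave open whether a methyl or methoxy group in place of the halogen would show the same dependence. They also leave open whether a plain acetyl group on the nitrogen would do so.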